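Nitro in place of chloro on the shared core

A few compounds are considered here, and "the series" means these few. Any claim that something is new, unique, unknown or untested is made for them only; others in the source may bear on it.

Compound 1 `O=C1/C(=C/c2cccc(F)c2)CCc2ccccc21`: 8010 nM
Compound 2 `O=C1/C(=C/c2cccc(Cl)c2)CCCc2ccccc21`: 9440 nM

In a functional assay on CCRF-CEM cells (Homo sapiens) for inhibition (a higher number here means a weaker inhibitor, a lower number a stronger inhibitor), compound 2, at 9440 nM, stands level with compound 1, the two numbers lying within the scatter of each other. Compound 3 `O=C1/C(=C/c2cccc([N+](=O)[O-])c2)CCCc2ccccc21` keeps the core of compound 2 and differs from it as follows: nitro in place of chloro on an aromatic carbon. This places nitro in place of chloro on an aromatic carbon, meta to a large group. Within the data shown here, no measured pair shows this change, and no step beyond the scatter is expected in this assay, in either direction. The expected change is a 1.2-fold lower number from compound 2 to compound 3 (0.07 log units; within the scatter). Compound 3 is estimated at 8000 nM, with an expected range from 2500 nM to 20000 nM.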

Compound 3, half-maximal inhibitory concentration: 7720 nM
Beside the measured number, compound 3's estimate is 1.0-fold (0.02 log units) above it, within the range that was stated.
By their numbers in this assay, from the lowest: compounds 3, 1 and 2 (each within the scatter of the next).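

In this assay, nitro in place of chloro on an aromatic carbon, meta to a large group, gives a 1.2-fold lower number from compound 2 to compound 3 (0.09 log units; within the scatter). At this position, then, the exchange of chloro for nitro, which enters with hydrogen-bond acceptors and more heavy atoms, brings no step beyond the scatter. No measurement shown accounts for this result. Going by these compounds, what remains open is whether an amine or a carboxylic acid on this same aromatic carbon would also stay within the scatter of compound 2 in this assay, or would bring a step beyond it.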